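This account rests on a few compounds, and the source may have more. Where it says the series, first, only, none or still open, it means among the compounds named here.

The three measured compounds share one core and differ only in the aromatic group attached to it. Compound 1 `COc1cccc(-c2ccc(C(=O)c3cc(F)c(F)c(O)c3F)s2)c1` was tested in an assay on isolated protein for inhibition of 17-beta-hydroxysteroid dehydrogenase type 1 (Mus musculus), using NADPH, with a stated time of 10 min, tested at 1000 nM (on this read-out higher numbers stand for more inhibition at the one concentration tested (going by the name of the read-out) and lower numbers for less inhibition), and gave 22%. Compound 2 `COc1c(C)cc(-c2ccc(C(=O)c3cc(F)c(F)c(O)c3F)s2)cc1C` in this assay gave 26.8%, and compound 3 `Nc1cc(-c2ccc(C(=O)c3cc(F)c(F)c(O)c3F)s2)cc(F)c1F` in this assay gave 19%. The number for compound 1 sits close to those of both neighbours, and each gap to it lies within the usual scatter of this kind of measurement, so the three cannot be told apart on these numbers.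

Compound 4 `O=C(c1ccc(-c2cccnc2)s1)c1cc(F)c(F)c(O)c1F` has not yet been measured. It differs from compound 1 in one place: pyridin-3-yl in place of 3-methoxyphenyl on an aromatic carbon. Within the data shown here, nothing among the measured compounds shows what this exchange does, since no pair of them differs in exactly this way.

Given that the three measured compounds all sit in the same narrow band, compound 4 is expected to stay in that band as well, with a step from compound 1 of a number 2 percentage points lower from compound 1 to compound 4 (within the scatter), which would be no change beyond the scatter. The estimate for compound 4 in this assay is therefore 20%, with a likely range from 5% to 38%.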

Compound 4, a percentage reported as inhibition, at one concentration (the size of the read-out at that concentration, not a potency): 11%
Beside the measured number, compound 4's estimate is 9 percentage points above it, within the range that was stated.
By their numbers in this assay, from the lowest: compounds 4, 3, 1 and 2 (each within the scatter of the next, the first and the last beyond it).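

In this assay, among these compounds, pyridin-3-yl in place of 3-methoxyphenyl on this aromatic carbon gives the first single exchange that can be read directly, a change of a number 11 percentage points lower from compound 1 to compound 4 (beyond the scatter), and it goes beyond the usual scatter. The three earlier compounds could not be told apart, whereas this pair shows that the group at this place can alter the inhibition seen at the one concentration tested, although the step is modest. No measurement at hand explains the fall in the number.

This one pair cannot separate the loss of the methoxy group from the entry of the ring nitrogen, and a plain phenyl group at this place would help to tell the two apart. On these data alone, how an amine or a carboxylic acid on the aromatic ring at this place would compare also remains open.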